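Benzyl in Place of Ethyl on a Shared Core

The compounds below may be only part of what the source reports. "The series", "measured", "known", "first", "only" and "open" are said of these compounds alone.

In an ADME assay on cells (Homo sapiens) for cytotoxicity, read by polymerase chain reaction, with a stated time of 3 days (on this read-out higher numbers stand for lower toxicity in this test and lower numbers for higher toxicity in this test), two compounds have been tested so far. Compound 1, `Nc1nc(Cl)c(-c2ncco2)c(N[C@@H]2C[C@H](CO)[C@@H](O)[C@H]2O)n1`, gives only a limit of the test rather than a number: > 25000 nM. That limit is the limit of > 25000 nM in this assay, at which 1 of the 2 values shown sits. Compound 2, `CCNc1nc(C)c(-c2nc3ccccc3s2)c(N[C@@H]2C[C@H](CO)[C@@H](O)[C@H]2O)n1`, gives 12000 nM in this assay. For the measured compounds named here, of the two results, that of compound 2 is the only true number, the other being a limit, so no order between the two compounds can be drawn. Compound 3, `Cc1nc(NCc2ccccc2)nc(N[C@@H]2C[C@H](CO)[C@@H](O)[C@H]2O)c1-c1nc2ccccc2s1`, has not yet been measured. It differs from compound 2 in one place: phenyl in place of methyl on a saturated chain carbon bound to a nitrogen on an aromatic ring. Going by the values given here, no step between two measured compounds is known here, so the size of this change in this assay cannot be read off from another pair. The expectation is a step from compound 2 to compound 3 of a 1.7-fold lower number from compound 2 to compound 3 (0.23 log units; within the scatter), towards a lower number, a little beyond the usual scatter. Compound 3 is therefore estimated at 7000 nM, within a range from 2500 nM to 25000 nM.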

Compound 3, half-maximal cytotoxic concentration: 9000 nM
For compound 3 the middle estimate is 1.3-fold (0.11 log units) below the measured one; the measured number falls inside the stated range.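

For the compounds shown here, until now no two measured compounds differed in only one place, so this is the first reading of this position in this assay: with benzyl in place of ethyl, the data show a 1.3-fold lower number from compound 2 to compound 3 (0.12 log units; within the scatter). The two compounds therefore cannot be told apart in this test, even though a phenyl, with its six heavy atoms and one six-membered aromatic ring, stands where a methyl of one heavy atom stood, so at least this one enlargement of the group on the saturated chain carbon leaves no reading beyond the usual scatter. Going by these compounds alone, nothing measured here offers a reason for this result, and the single limit among the values does not bear on this pair.

Going by these compounds, a single change says little about the position as a whole, so it remains open whether a longer chain such as phenylethyl, or a phenyl carrying an amine or a carboxylic acid, would give a step beyond the scatter. On these data alone, whether benzyl in place of ethyl would read the same way on a different core also remains open.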